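From compound 1 to compound 3: a carbonyl enters

The source may hold more compounds than are shown below. What is called first, only, known or untested is meant among the compounds shown, and "the series" means these compounds.

Of the compounds shown here, two have numbers so far. In a functional assay on OVCAR-3 cells (Homo sapiens) for antiproliferative activity, read by MTT assay, with a stated time of 24 h (a lower number here means a stronger inhibitor, a higher number a weaker inhibitor), compound 1 `O=C(NNc1cccc(Cl)c1)c1cccc(NS(=O)(=O)c2cnc(O)nc2O)c1` gives 8040 nM and compound 2 `O=C(NNc1cccc(Cl)c1)c1ccccc1NS(=O)(=O)c1cnc(O)nc1O` gives 5520 nM. Going by the values given here, these two values lie within the scatter of each other, so compound 1 stands level with the only other measured compound, and neither can be ranked.

The next compound is compound 3 `O=C(NNC(=O)c1ccccc1Cl)c1cccc(NS(=O)(=O)c2cnc(O)nc2O)c1`, which keeps the core of compound 1. Its change is (2-chlorophenyl)carbonyl in place of 3-chlorophenyl on an amine nitrogen. Among the compounds with values here, no measured pair isolates a change at this place, so the data offer no direct precedent. Within the data shown here, the only guide is the general level of the series, set by compound 1 at 8040 nM.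

With no evidence favouring either direction, the expected change in this assay is a 1.1-fold lower number from compound 1 to compound 3 (0.06 log units; within the scatter), an estimated step that stays within the scatter. For compound 3 the estimated value is 7000 nM. The expected range for compound 3 runs from 2500 nM to 20000 nM, kept wide because so little has been measured.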

Compound 3, half-maximal inhibitory concentration: 7300 nM
Compound 3: the middle estimate sits 1.0-fold (0.02 log units) below what was measured; low and high end bracket the measured number.
By their numbers in this assay, from the lowest: compounds 2, 3 and 1 (each within the scatter of the next).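

In this assay, going by these compounds alone, (2-chlorophenyl)carbonyl in place of 3-chlorophenyl on an amine nitrogen whose other neighbour is an amide-type nitrogen gives a 1.1-fold lower number from compound 1 to compound 3 (0.04 log units; within the scatter), the only measured step at this place. The exchange brings in a carbonyl and a hydrogen-bond acceptor, yet the antiproliferative read-out in this pair stays within the scatter, so neither feature shows a measurable effect on the number when the two groups are exchanged as a whole. No separate measurement bears on this result.

Going by these compounds, the step alters the carbonyl and the chlorine placement in one exchange, so the share of each cannot be read, and it remains open whether 2-chlorophenyl without the carbonyl, or (3-chlorophenyl)carbonyl, would read the same in this assay. Also open, on these data alone, is whether a group of another kind on this nitrogen, such as a carboxylic acid, an amine or a longer alkyl chain, would give a step beyond the scatter, and whether the same exchange on compound 2 would behave as it does on compound 1.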